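Series notes: amide variation on the shared core

This account rests on a few compounds, and the source may have more. Where it says the series, first, only, none or still open, it means among the compounds named here.

Measured compounds:
- compound 1 `CCn1c(-c2cnc(C)nc2)nc2c(N[C@H]3CCN(C(=O)C4CCC4)C3)ncnc21`: 2.3 L/kg
- compound 2 `CCn1c(-c2cnc(C)nc2)nc2c(O[C@H]3CCN(C(=O)C4CCC4)C3)ncnc21`: 1.4 L/kg

Both values come from an ADME assay (Canis lupus familiaris, strain Beagle) for pharmacokinetics; on this read-out higher numbers stand for wider distribution into tissues and lower numbers for narrower distribution. Compound 1 gives 2.3 L/kg and compound 2 gives 1.4 L/kg in this assay; the two numbers lie within the usual scatter of each other, so neither compound stands apart from the other on this read-out. Among the compounds with values here, no pair of measured compounds differs in a single place, so nothing is known yet about how one change on the shared core moves this assay.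

Compound 3 `CCn1c(-c2cnc(C)nc2)nc2c(N[C@H]3CCN(C(=O)N4CC(OC)C4)C3)ncnc21` is not yet measured. It differs from compound 1 as follows: 3-methoxyazetidin-1-yl in place of cyclobutyl on a carbonyl carbon. The carbonyl and the amide-type nitrogen in a ring are kept; only the group on the carbonyl carbon changes.

Within the data shown here, with no measured single-point step to lean on, the expectation rests on the two measured values alone. The step of a 1.4-fold lower number from compound 1 to compound 3 (0.16 log units; within the scatter) is expected to be small, toward a lower number, and not beyond the scatter. Compound 3 is estimated at 1.6 L/kg in this assay, with a range from 0.9 L/kg to 2.8 L/kg.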

Compound 3, volume of distribution: 1.9 L/kg
Compound 3: middle estimate off by 1.2-fold (0.07 log units), on the low side; the measured number falls inside the stated range.
By their numbers in this assay, from the lowest: compounds 2, 3 and 1 (each within the scatter of the next).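

Within the data shown here, this is the first single-place step: in this assay, replacing cyclobutyl with 3-methoxyazetidin-1-yl on a carbonyl carbon gives a 1.2-fold lower number from compound 1 to compound 3 (0.08 log units; within the scatter). At this position, then, an all-carbon four-membered ring can give way to a larger group with a ring nitrogen, a methoxy oxygen and 1 hydrogen-bond acceptor, where cyclobutyl has 0, without a shift beyond the scatter on this read-out. No measurement at hand explains this result.

This single step does not show whether the position stays as forgiving for groups of a different kind on the carbonyl carbon, such as a carboxylic acid, an open-chain dimethylamino group or a longer alkyl chain such as n-hexyl. Also open, going by these compounds, is whether 3-methoxyazetidin-1-yl would give a similarly small step on the carbonyl of compound 2, and whether the methoxy group itself contributes anything, which a plain azetidin-1-yl on the same carbonyl carbon would help to separate.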